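The source may report more compounds than this note shows. Statements on the series, on what has been measured and on what is new or still open speak of the compounds shown alone.

Among the compounds with values here, in an ADME assay on microsomes from liver (Mus musculus) for metabolic stability, read by LC-MS, with a stated time of 30 min, tested at 1 uM (on this read-out higher numbers stand for a more stable compound and lower numbers for a less stable compound), two compounds have numbers so far. Compound 1 (`O=C(NCc1ccc(S(=O)(=O)c2cccc(C(F)(F)F)c2)cc1)c1cc2cnccc2[nH]1`) gives 49%, and compound 2 (`O=C(NCc1ccc(S(=O)(=O)c2cc(F)cc(F)c2)cc1)c1cnc2nccn2c1`) gives 71%, the higher of the two and a gap beyond the usual scatter. These two differ in more than one place, so their gap cannot be tied to any single change. Compound 3 (`O=C(NCc1ccc(S(=O)(=O)c2cccc(C(F)(F)F)c2)cc1)c1cnc2nccn2c1`) keeps all of compound 2 except one group: it has 3-(trifluoromethyl)phenyl in place of 3,5-difluorophenyl on a sulfonyl sulfur. Within the data shown here, no measured pair shows this change alone. The entering group is also found in compound 1, which stands at 49%, so a modest fall is expected, though it may not clear the scatter. The expected step is a number 10 percentage points lower from compound 2 to compound 3 (within the scatter). Compound 3 is estimated at 61%, with an expected range of 44% to 77%.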

Compound 3, percent of the compound remaining: 27%
The estimate for compound 3 lay 34 percentage points above the measured number; measured number below the stated range.
By their numbers in this assay, from the lowest: compound 3; then compound 1; then compound 2.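

In this assay, the group on the sulfonyl sulfur proves decisive on the core of compound 2: 3-(trifluoromethyl)phenyl in place of 3,5-difluorophenyl gives a number 44 percentage points lower from compound 2 to compound 3 (beyond the scatter). The core matters as well, since with 3-(trifluoromethyl)phenyl held fixed, the change of group on the carbonyl carbon gives a number 22 percentage points lower from compound 1 to compound 3 (beyond the scatter). The same core therefore carries both the highest and the lowest number of the three compounds, so neither the core nor the sulfonyl group sets the number alone.

Nothing shown explains why either step occurs. On these data alone, it remains open how 3,5-difluorophenyl would fare on the core of compound 1, and whether a plain phenyl or a cyclohexyl on the sulfonyl sulfur would stand nearer to compound 2 or compound 3.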